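A few compounds are considered here, and "the series" means these few. Any claim that something is new, unique, unknown or untested is made for them only; others in the source may bear on it.

Measured so far:
compound 1, `Cc1ccccc1Nc1nc(Nc2cc(Cl)ccn2)ncc1Cl`: > 100000 nM
compound 2, `CN1CCN(c2ccc(Nc3ncc(Cl)c(NCc4ccccc4)n3)nc2)CC1`: 17300 nM

In a functional assay on MCF7 cells (Homo sapiens) for inhibition, read by CCK-8 assay, with a stated time of 48 h (on this read-out lower numbers stand for stronger inhibition of growth and higher numbers for weaker inhibition of growth), compound 1 gives only a limit, > 100000 nM, so no number is known for it. For the measured compounds named here, compound 2 is the one compound with a number in this assay, 17300 nM. The other entry sits at a limit (the limit of > 100000 nM in this assay, at which 1 of the 2 values shown sits). Going by the values given here, compound 1 and compound 2 differ in more than one place, so their two values show only that compound 2 has a measured number and compound 1 does not.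

Compound 3, `Cc1cc(C)c(Nc2nc(Nc3ccc(N4CCN(C)CC4)cn3)ncc2Cl)c(C)c1`, is not yet measured. It differs from compound 2 in one place: 2,4,6-trimethylphenyl in place of benzyl on a nitrogen on an aromatic ring. Among the compounds with values here, no measured pair isolates this change, so no step size is on record for it. Compound 3 is expected to come out somewhat weaker than compound 2, a step of a 1.7-fold higher number from compound 2 to compound 3 (0.24 log units; within the scatter), with wide uncertainty around it. The estimate for compound 3 in this assay is 30000 nM, between 8000 nM and 100000 nM.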

Compound 3, concentration for 50% growth inhibition: 9470 nM
The estimate for compound 3 lay 3.2-fold (0.50 log units) above the measured number; measured number inside the range.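

In this assay, for the compounds shown here, the first step on record at this place, benzylamino to (2,4,6-trimethylphenyl)amino, gives a 1.8-fold lower number from compound 2 to compound 3 (0.26 log units; within the scatter). The two values therefore cannot be told apart, so this nitrogen carries either the benzyl or the 2,4,6-trimethylphenyl group with no readable difference on this read-out, a comparison that compounds 1 and 2 could not give. Nothing on record bears on why these two groups read alike.

Open, on these data alone, is whether any group on this nitrogen moves the number beyond the scatter, since a single step within it sets no trend. An unsubstituted phenyl, a longer phenylethyl chain or a ring carrying a carboxylic acid or an amine would test whether the ring itself or its substituents matter here.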